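Pentyl amide variant of the dihydrofuran series

A few compounds are considered here, and "the series" means these few. Any claim that something is new, unique, unknown or untested is made for them only; others in the source may bear on it.

Measured so far in a functional assay on QGY7701 cells (Homo sapiens) for cytotoxicity, read by MTT assay, with a stated time of 24 h; on this read-out higher numbers stand for weaker inhibition and lower numbers for stronger inhibition:
- compound 1 `C=CC1=C(C(=O)O)C(c2ccc(OC)cc2)OC1` gives > 100000 nM, a limit of the assay
- compound 2 `C=CC1=C(C(=O)Nc2ccccc2OC)C(c2ccc(F)cc2)OC1` gives 52800 nM
- compound 3 `C=CC1=C(C(=O)Nc2ccccc2OC)C(c2ccc(Cl)c(Cl)c2)OC1` gives > 100000 nM, a limit of the assay

For the measured compounds named here, compound 2 holds the only numeric value among the three; the other two results sit at the limit of > 100000 nM in this assay, at which 2 of the 3 values shown sit. Going by the values given here, the single step between compounds that differ in one place is an at least 1.8-fold higher number from compound 2 to compound 3 (0.27 log units; that floor lies within the scatter), which concerns the aryl group on the saturated ring carbon, not the amide substituent.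

Compound 4 `C=CC1=C(C(=O)NCCCCC)C(c2ccc(F)cc2)OC1` is not yet measured. It differs from compound 2 by pentyl in place of 2-methoxyphenyl on an amide-type nitrogen. Among the compounds with values here, no measured step touches the amide nitrogen, so the change from compound 2 to compound 4 has no direct precedent in this set; the only step available, from compound 2 to compound 3, reached a limit and says nothing about the amide side.

Within the data shown here, with no guiding step, compound 4 is expected to land near compound 2, with a step of a 1.3-fold higher number from compound 2 to compound 4 (0.12 log units; within the scatter) that is not expected to exceed the scatter in either direction. The estimate for compound 4 is 70000 nM, in the range 20000 nM to 200000 nM, with a real chance that this assay again returns only a limit.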

Compound 4, half-maximal inhibitory concentration: > 100000 nM
Compound 4 was reported as a limit; the forecaster's own chance of this, stated with the estimate: 45%; middle value at least 1.4-fold (0.15 log units) from the limit.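

For the compounds shown here, this is the first step at the amide nitrogen in this assay: pentyl in place of 2-methoxyphenyl gives an at least 1.8-fold higher number from compound 2 to compound 4 (0.27 log units; that floor lies within the scatter), and its true size cannot be read. Compound 4 gives > 100000 nM, a limit of the assay and not a number. Compound 2 remains the only compound with a numeric value, and a change on the amide-type nitrogen now joins the change on the saturated ring carbon in ending at a limit: the limit of > 100000 nM in this assay, at which 3 of the 4 values shown sit.

Open, from the compounds shown here alone, is whether a shorter chain such as ethyl, or a pentyl chain ending in an amine or a carboxylic acid, would return a number in this assay. Also open, going by these compounds, is how an unsubstituted phenyl on the amide nitrogen would read against compound 2, which would show whether the methoxy group matters.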